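A few compounds are considered here, and "the series" means these few. Any claim that something is new, unique, unknown or untested is made for them only; others in the source may bear on it.

In a functional assay on N2a cells (Mus musculus) for inhibition (a higher number here means a weaker inhibitor, a lower number a stronger inhibitor), compound 1 `CCCCCCCC[C@@H](C/C=C/CCC(=O)NC/C(=C/Cl)[C@]12O[C@H]1[C@H](OC(C)=O)CCC2=O)OC` gives 4000 nM and compound 2 `CCCCCCCC[C@@H](C/C=C/CCC(=O)NC/C(=C/Cl)[C@]12O[C@H]1[C@H](O)CCC2=O)OC` gives 4000 nM, so compound 2 stands level with compound 1. Compound 3 `CCCCCCCC[C@@H](C/C=C/CCC(=O)NC/C(=C/Cl)C1=CCC[C@@H](OC(C)=O)C1=O)OC` differs from compound 2 in a larger way: a group of 11 heavy atoms (8 carbon, 3 oxygen; one six-membered non-aromatic ring of carbon only) in place of a group of 9 heavy atoms (6 carbon, 3 oxygen; one three-membered non-aromatic ring with 1 hetero atom, one six-membered non-aromatic ring of carbon only), on a double-bonded chain carbon bound to a double-bonded chain carbon and a saturated chain carbon. For the measured compounds named here, the one measured step, no change at the digits printed from compound 1 to compound 2 (within the scatter), involved only an acetyl on an oxygen, so it is a weak guide to this exchange. As far as these compounds go, no step beyond the scatter is confidently expected, and the direction remains open. The expected step is a 1.3-fold higher number from compound 2 to compound 3 (0.10 log units; within the scatter). Compound 3 is estimated at 5000 nM, within an expected range of 1500 nM to 20000 nM.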

Compound 3, half-maximal inhibitory concentration: 4000 nM
Beside the measured number, compound 3's estimate is 1.3-fold (0.10 log units) above it; the range from low to high includes it.
By their numbers in this assay, from the lowest: compounds 1, 2 and 3 (each within the scatter of the next).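

In this assay, the exchange on the double-bonded chain carbon bound to a double-bonded chain carbon and a saturated chain carbon brings no change at the digits printed from compound 2 to compound 3 (within the scatter). The change here goes well beyond an acetyl on an oxygen: the three-membered ring with 1 hetero atom leaves, and the entering group has 0 hydrogen-bond donors and 1 defined stereocentre, against 1 and 3 in the group that leaves. No measurement at hand explains this result. As far as these compounds go, all three compounds share the same long chain with its methoxy group, so what a carboxylic acid in place of that methoxy group, or a longer chain, would do in this assay remains open.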